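The compounds below may be only part of what the source reports. "The series", "measured", "known", "first", "only" and "open" are said of these compounds alone.

- compound 1 `O=C1/C(=C\c2ccc(Cl)cc2)S/C(=N/c2ccccc2)N1Cc1ccncc1`: 28800 nM
- compound 2 `CC(C)c1ccc(/C=C2/S/C(=N/c3ccccc3)N(Cc3ccncc3)C2=O)cc1`: 32300 nM

Among the measured compounds shown here, in a functional assay on HepG2 cells (Homo sapiens) for cytotoxicity, read by MTT assay, with a stated time of 48 h (on this read-out higher numbers stand for weaker inhibition and lower numbers for stronger inhibition), compound 1 gives 28800 nM, and its only neighbour, compound 2, cannot be told apart from it: a 1.1-fold higher number from compound 1 to compound 2 (0.05 log units; within the scatter). Compound 3 `COc1ccc(OC)c(/C=C2/S/C(=N/c3ccccc3)N(Cc3ccncc3)C2=O)c1` is not yet measured. It differs from compound 1 by 2,5-dimethoxyphenyl in place of 4-chlorophenyl on a double-bonded chain carbon bound to a double-bonded ring carbon.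

For the measured compounds named here, the one measured step that bears on this change is the step to compound 2, which alters the same aromatic ring: a 1.1-fold higher number from compound 1 to compound 2 (0.05 log units; within the scatter). Going by the values given here, that is thin evidence, and no compound with methoxy groups has been measured, so no step beyond the scatter is expected, with wide uncertainty. The expected step is a 1.0-fold lower number from compound 1 to compound 3 (0.01 log units; within the scatter). Compound 3 is estimated at 28000 nM, with an expected range of 12000 nM to 65000 nM.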

Compound 3, half-maximal inhibitory concentration: 35800 nM
The estimate for compound 3 lay 1.3-fold (0.11 log units) below the measured number; measured number inside the range.
By their numbers in this assay, from the lowest: compounds 1, 2 and 3 (each within the scatter of the next).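

In this assay, 2,5-dimethoxyphenyl in place of 4-chlorophenyl gives a 1.2-fold higher number from compound 1 to compound 3 (0.09 log units; within the scatter) and in place of 4-isopropylphenyl gives a 1.1-fold higher number from compound 2 to compound 3 (0.04 log units; within the scatter) on the same carbon. This adds a new kind of group to the series: a bigger aromatic substituent with hydrogen-bond acceptors still cannot be told apart from the other two on this read-out. Nothing measured alongside these numbers accounts for how close they lie.

As far as these compounds go, whether an amine or a carboxylic acid on this ring would give a step beyond the scatter remains open. So does whether changes elsewhere on the shared core would do so.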